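The source may report more compounds than this note shows. Statements on the series, on what has been measured and on what is new or still open speak of the compounds shown alone.

Measured so far:
- compound 1, `Cc1ccc(S(=O)(=O)c2cnc3cc(Cl)ccc3c2N2CCC(C)CC2)cc1`: 94%
- compound 2, `CC1CCN(c2c(S(=O)(=O)c3ccc(Cl)cc3)cnc3cc(Cl)ccc23)CC1`: 91%
- compound 3, `Cc1ccc2ncc(S(=O)(=O)c3ccc(C#N)cc3)c(N3CCC(C)CC3)c2c1`: 55%

These three compounds were tested in an assay on isolated protein for displacement of a labelled ligand from metabotropic glutamate receptor 5 (Homo sapiens), with a stated time of 60 min, tested at 1 uM; a lower number here means less inhibition, a higher number more inhibition at the concentration tested (going by the name of the read-out). Compound 1 gives 94% in this assay, compound 2 gives 91%, and compound 3 gives 55%.

Compound 1 and compound 2 differ in one place: chloro in place of methyl on an aromatic carbon. That change made a step of a number 3 percentage points lower from compound 1 to compound 2 (within the scatter), so the two values cannot be told apart.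

Compound 4, `CC1CCN(c2c(S(=O)(=O)c3ccc(C#N)cc3)cnc3ccc(Cl)cc23)CC1`, has not yet been measured. It differs from compound 3 in one place: chloro in place of methyl on an aromatic carbon. For the measured compounds named here, this is the same kind of change as the one from compound 1 to compound 2, but not at the same place: in compound 1 the group sits on a six-membered aromatic ring of carbon only, para to a large group, while in compound 3 it sits on a six-membered aromatic ring of carbon only that is part of a fused or bridged system of two rings, meta to a fused ring and para to a fused ring. The difference between the core of compound 3 and the core of compound 1 is not broken down here.

Going by the earlier step, compound 4 is expected to stay close to compound 3, with a step of a number 5 percentage points higher from compound 3 to compound 4 (within the scatter) in this assay, because the same kind of change gave a number 3 percentage points lower from compound 1 to compound 2 (within the scatter). The estimate rests on a single earlier step at a different place, so it is held loosely. Compound 4 is expected to give about 60% in this assay, most likely between 42% and 78%.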

Compound 4, a percentage reported as inhibition, at one concentration (the size of the read-out at that concentration, not a potency): 31%
Estimate against measurement, compound 4: 29 percentage points above, outside the stated range (below it).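

In this assay, swapping a methyl for a chloro did not behave the same way on the two cores: the same change on two cores in this assay, a number 3 percentage points lower (within the scatter) from compound 1 to compound 2 and a number 24 percentage points lower (beyond the scatter) from compound 3 to compound 4, 21 percentage points apart, beyond the scatter of two such steps. On the core of compound 3, where the change sits on an aromatic carbon of a six-membered aromatic ring of carbon only, part of a fused or bridged system of two rings, the swap gave a number 24 percentage points lower from compound 3 to compound 4 (beyond the scatter), so a harmless result on one core cannot be assumed to hold on another in this series. This does not show why the two steps differ, since the two pairs differ both in where the swap takes place and in the rest of the molecule, and each step rests on a single pair of compounds read at one concentration.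

The compounds shown leave open whether a fluoro or a methoxy group on that same aromatic carbon would give a number nearer to that of compound 3 or that of compound 4. They also leave open whether the nitrile shared by compound 3 and compound 4 plays any part in the larger step, which a comparison with an amide or a methoxy group in its place could begin to test.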